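The compounds below may be only part of what the source reports. "The series", "measured", "known", "first", "only" and "open" are said of these compounds alone.

In a functional assay on HeLa cells (Homo sapiens) for antiproliferative activity, read by CCK-8 assay, with a stated time of 72 h, tested at 2 uM (a higher number here means a stronger effect of the compound at the concentration tested, a lower number a weaker effect), compound 3 `CN(C(=S)SCc1ccc(C(=O)Nc2ccccc2N)cc1)c1cccnc1` gives 16%, the lowest of the three numbers measured. Compound 2 `Nc1ccccc1NC(=O)c1ccc(CSC(=S)N2CCc3ccccc32)cc1` gives 38% in this assay, and compound 1 `Nc1ccccc1NC(=O)c1ccc(CSC(=S)N2CCN(c3ccccc3)CC2)cc1` gives 62.2% in this assay. For the measured compounds named here, only one measured pair differs in a single place: a number 22 percentage points lower from compound 2 to compound 3 (beyond the scatter), with methyl(pyridin-3-yl)amino in place of 2,3-dihydro-1H-indol-1-yl on a thiocarbonyl carbon. Compound 4 `Nc1ccccc1NC(=O)c1ccc(CSC(=S)N2CCCc3ccccc32)cc1` differs from compound 3 in that (1,2,3,4-tetrahydroquinolin-1-yl in place of methyl(pyridin-3-yl)amino on a thiocarbonyl carbon). The group leaving compound 3 is the very group whose entry accompanied that loss, and the group entering compound 4 again brings a non-aromatic ring with one hetero atom joined to a six-membered aromatic ring of carbon only, as in compound 2. That measured step therefore bears directly on this one, and a step of about the same size in the opposite direction is expected, namely a number 22 percentage points higher from compound 3 to compound 4 (beyond the scatter). For compound 4 in this assay the estimate is 38%, within a range from 20% to 58%.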

Compound 4, a percentage reported as inhibition, at one concentration (the size of the read-out at that concentration, not a potency): 26.1%
Compound 4: the middle estimate sits 11.9 percentage points above what was measured; the range from low to high includes it.
By their numbers in this assay, from the lowest: compound 3; then compound 4; then compound 2; then compound 1.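

In this assay, the tetrahydroquinoline group does recover activity at this thiocarbonyl carbon, with a number 10.1 percentage points higher from compound 3 to compound 4 (beyond the scatter), so the fall seen with methyl(pyridin-3-yl)amino is not specific to the 2,3-dihydro-1H-indol-1-yl comparison. The two groups with a non-aromatic ring joined to a carbon-only aromatic ring are not interchangeable, however, as a number 11.9 percentage points lower from compound 2 to compound 4 (beyond the scatter) shows, and the position therefore distinguishes even between these closely matched groups. Nothing available explains either step.

From the compounds shown here alone, it remains open whether methyl(phenyl)amino on the same thiocarbonyl carbon would read closer to compound 3 or to compound 4, which would separate the pyridine nitrogen from the closed ring in these comparisons. Each figure also comes from a single concentration, so these steps do not give the potency of any compound.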